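The source may hold more compounds than are shown below. What is called first, only, known or untested is meant among the compounds shown, and "the series" means these compounds.

Measured so far in a functional assay on MDA-MB-231 cells (Homo sapiens) for antiproliferative activity, read by CCK-8 assay, with a stated time of 48 h; on this read-out lower numbers stand for stronger inhibition and higher numbers for weaker inhibition:

Compound 1 `C=CC(=O)NCCOc1ccc(Oc2c(-c3ccc(F)cc3)sc3cc(O)ccc23)cc1` gives > 50000 nM, which is a limit of the assay.
Compound 2 `C=C(C)C(=O)NCCOc1ccc(Oc2c(-c3ccc(F)cc3)sc3cc(O)ccc23)cc1` gives > 50000 nM, which is a limit of the assay.
Compound 3 `C=CC(=O)N1CC(Oc2ccc(Oc3c(-c4ccc(F)cc4)sc4cc(O)ccc34)cc2)C1` gives > 50000 nM, which is a limit of the assay.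

All three values sit at one limit, (the limit of > 50000 nM in this assay, at which 3 of the 3 values shown sit), so no ordering among them can be read. The change methyl in place of hydrogen on a double-bonded chain carbon bound to a carbonyl carbon gives a step that the two limits leave unreadable from compound 1 to compound 2. The two cores differ by 1-(vinylcarbonyl)azetidin-3-yl in place of 2-((vinylcarbonyl)amino)ethyl on an oxygen on an aromatic ring, giving a step that the two limits leave unreadable from compound 1 to compound 3.

Compound 4 `C=C(C)C(=O)N1CC(Oc2ccc(Oc3c(-c4ccc(F)cc4)sc4cc(O)ccc34)cc2)C1` is not yet measured in this assay. It differs from compound 3 by methyl in place of hydrogen on a double-bonded chain carbon bound to a carbonyl carbon, at the same place as the change from compound 1 to compound 2, so it is the same change. Because compound 1 and compound 2 both sit at the limit of > 50000 nM in this assay, at which 3 of the 3 values shown sit, the step from compound 3 to compound 4 in this assay is expected to be a step that the limit leaves unreadable from compound 3 to compound 4, though an unreadable step leaves the size open. Compound 4 is therefore expected to give 60000 nM, with a range from 30000 nM to 200000 nM, and most likely only a limit again.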

Compound 4, half-maximal inhibitory concentration: > 50000 nM
Compound 4: no number, only a limit; the forecaster's own chance of this, stated with the estimate: 85%; the middle value does not contradict the limit.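

Compound 4 gives > 50000 nM, which is a limit of the assay, so none of its steps to compound 1, compound 2 or compound 3 can be read: the limit of > 50000 nM in this assay, at which 4 of the 4 values shown sit.

The compounds shown leave open whether methyl in place of hydrogen, or 1-(vinylcarbonyl)azetidin-3-yl in place of 2-((vinylcarbonyl)amino)ethyl, changes antiproliferative activity at all.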